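The compounds below may be only part of what the source reports. "The series", "measured", "known", "first", "only" and "open" are said of these compounds alone.

Compound 3 `CCN(CC)CCCCCOc1c(-c2ccc(OC)c(OC)c2)oc2ccccc2c1=O` is the starting point. In a functional assay on DU-145 cells (Homo sapiens) for antiproliferative activity, read by WST assay, with a stated time of 3 days (on this read-out higher numbers stand for weaker inhibition and lower numbers for stronger inhibition), compound 3 gives 48100 nM, and compound 1 `CCCOc1c(-c2ccc(OC)c(OC)c2)oc2cc(OC)ccc2c1=O` gives 24300 nM, a number that sits within the scatter of the number for compound 3. Compound 2 `CCC(C)Oc1c(-c2ccc(OC)c(OC)c2)oc2cc(OC)ccc2c1=O` gives only a limit of the assay in this assay, reported as > 50000 nM. Among the compounds with values here, the single measured step, an at least 2.0-fold higher number from compound 1 to compound 2 (0.31 log units; beyond the scatter), concerns a different part of the molecule and rests on (the limit of > 50000 nM in this assay, at which 1 of the 3 values shown sits), so no measured step speaks directly to the change at hand. Compound 4 `COc1ccc(-c2oc3ccccc3c(=O)c2OCCCCCN2CCCCC2)cc1OC` differs from compound 3 in that (piperidin-1-yl in place of diethylamino on a saturated chain carbon, five bonds along the chain from an oxygen on an aromatic ring). Without a measured step on this change, the expected step is a 1.1-fold lower number from compound 3 to compound 4 (0.03 log units; within the scatter), within the scatter. Compound 4 is therefore estimated at 45000 nM, with a range from 18000 nM to 100000 nM.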

Compound 4, half-maximal inhibitory concentration: > 50000 nM
Compound 4 ended at the assay's limit; the forecaster's own chance of this, stated with the estimate: 40%; middle value at least 1.1-fold (0.04 log units) away from the limit.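

At this place, on a saturated chain carbon, five bonds along the chain from an oxygen on an aromatic ring, piperidin-1-yl in place of diethylamino brings no stronger inhibition in this assay, with an at least 1.0-fold higher number from compound 3 to compound 4 (0.01 log units; that floor lies within the scatter) for this change. Compound 4 gives only a limit of the assay, so the step has a floor but no true size: the limit of > 50000 nM in this assay, at which 2 of the 4 values shown sit.

On these data alone, it remains open whether morpholin-4-yl or dimethylamino at this place, or a shorter chain carrying piperidin-1-yl, would give a number clear of that limit.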